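Replacement of the chloro group on the shared core

This account rests on a few compounds, and the source may have more. Where it says the series, first, only, none or still open, it means among the compounds named here.

Measured compounds:
- compound 1 `N#Cc1c(Cl)nc(SCc2nc3ccccc3[nH]2)nc1-c1ccccc1`: 4.46 nM
- compound 2 `N#Cc1c(NC(N)=O)nc(SCc2nc3ccccc3[nH]2)nc1-c1ccccc1`: 3.37 nM
- compound 3 `N#Cc1c(-c2ccccc2)nc(SCc2nc3ccccc3[nH]2)nc1N1CCNCC1`: 5.81 nM

In a functional assay on U-937 cells (Homo sapiens) for cytotoxicity, read by MTT assay, with a stated time of 3 days (on this read-out lower numbers stand for stronger inhibition and higher numbers for weaker inhibition), compound 1 gives 4.46 nM, which is the second highest of the three numbers; compound 3 is its nearest neighbour and compound 2 its furthest, and both gaps lie within the scatter. Compound 4 `CN1CCN(c2nc(SCc3nc4ccccc4[nH]3)nc(-c3ccccc3)c2C#N)CC1` is not yet measured. It differs from compound 1 as follows: 4-methylpiperazin-1-yl in place of chloro on an aromatic carbon.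

For the measured compounds named here, two measured steps bear on this change, both replacing the same chloro group: a 1.3-fold lower number from compound 1 to compound 2 (0.12 log units; within the scatter) and a 1.3-fold higher number from compound 1 to compound 3 (0.11 log units; within the scatter). The step to compound 3 is the closer precedent, as piperazin-1-yl and 4-methylpiperazin-1-yl share the six-membered non-aromatic ring. Neither step moved the number beyond the scatter, so no step beyond the scatter is expected for compound 4 in this assay in either direction.

The estimate for compound 4 is therefore 5.5 nM, with a range of 2.5 nM to 12 nM, and an expected step of a 1.2-fold higher number from compound 1 to compound 4 (0.09 log units; within the scatter).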

Compound 4, half-maximal inhibitory concentration: 6.75 nM
Estimate against measurement, compound 4: 1.2-fold (0.09 log units) below; the measured number falls inside the stated range.
By their numbers in this assay, from the lowest: compounds 2, 1, 3 and 4 (each within the scatter of the next).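

In this assay, for the compounds shown here, the position also accepts 4-methylpiperazin-1-yl in place of chloro (a 1.5-fold higher number from compound 1 to compound 4 (0.18 log units; within the scatter)), and methyl in place of hydrogen on the ring amine nitrogen, a change the earlier compounds did not cover, stays within the scatter as well (a 1.2-fold higher number from compound 3 to compound 4 (0.07 log units; within the scatter)). The exchange of ureido for 4-methylpiperazin-1-yl also stays within the scatter (a 2.0-fold higher number from compound 2 to compound 4 (0.30 log units; within the scatter)), so chloro, ureido, piperazin-1-yl and 4-methylpiperazin-1-yl are not separated at this position by this read-out. Nothing available gives a cause for this flat result.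

Open, going by these compounds, is whether a carboxylic acid or a long alkyl chain on this aromatic carbon would move the number beyond the scatter. Also open, on these data alone, is whether a benzyl group on the piperazine nitrogen would do so, where methyl does not.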